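Acylation of the anilino nitrogen in a chalcone series

This account rests on a few compounds, and the source may have more. Where it says the series, first, only, none or still open, it means among the compounds named here.

Measured compounds:
compound 1, `Nc1ccc(C(=O)/C=C/c2ccc(Cl)cc2)cc1`, 54%
compound 2, `COc1ccc(/C=C/C(=O)c2ccc(NC(=O)CO[N+](=O)[O-])cc2)cc1`, 46%

The account follows one change made to compound 1. In a functional assay on the whole organism (strain albino) for inhibition, with Rattus norvegicus as the target, read by paw edema, with stated times of 30 min and 5 h, at a dose of 100 mg/kg by the oral route (a higher number here means more inhibition at the dose given (going by the name of the read-out), a lower number less inhibition), compound 1 gives 54%, and this is the higher of the two numbers shown, though the nearest number, that of compound 2 with 46%, lies within the scatter of it, so the two stand on a level. Among the compounds with values here, compound 2 carries an acylated nitrogen and a methoxy group where compound 1 carries a free amino group and a chlorine; no single step separates the two, so their values are only read side by side.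

Compound 3, `CC(Br)C(=O)Nc1ccc(C(=O)/C=C/c2ccc(Cl)cc2)cc1`, has not yet been measured in this assay. It differs from compound 1 by (1-bromoethyl)carbonyl in place of hydrogen on a nitrogen on an aromatic ring.

Within the data shown here, since no measured pair shows the effect of acylating this nitrogen on its own, the expectation rests on the two numbers alone. Compound 1 sits close to the acylated compound 2, which gives 46%, so no step beyond the scatter is expected from compound 1 to compound 3 in this assay, which is the expected step of a number 4 percentage points lower from compound 1 to compound 3 (within the scatter). Compound 3 is therefore estimated at 50%, expected to fall between 35% and 65%.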

Compound 3, a percentage reported as inhibition, in the whole organism at one dose (the size of the read-out at that dose, not a potency): 50%
Beside the measured number, compound 3's estimate shows no gap at the digits printed; the measured number falls inside the stated range.
By their numbers in this assay, from the lowest: compounds 2, 3 and 1 (each within the scatter of the next).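

Within the data shown here, compound 3 gives the first reading of a change at this one place: in this assay, putting (1-bromoethyl)carbonyl in place of hydrogen on a nitrogen on an aromatic ring gives a number 4 percentage points lower from compound 1 to compound 3 (within the scatter), so the free amino group and its acylated form stand on a level. Compounds 1 and 2 differ in two places and could not isolate this, whereas here the nitrogen alone changes, and 5 heavy atoms, a bromine among them, enter there with no step beyond the scatter at this single oral dose. No measurement at hand says how either compound acts or what becomes of the acylated nitrogen in the animal.

The compounds shown leave open whether the bromine has any part in this reading, which an unbrominated propanoyl group or a plain acetyl group on the same nitrogen would test. They also leave open how the nitrooxyacetyl group of compound 2 would read on the chlorine-bearing core of compound 1, as the step between compound 2 and either other compound cannot be read.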